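Propyl in Place of Isopropyl, Carried to a Second Core

A few compounds are considered here, and "the series" means these few. Any claim that something is new, unique, unknown or untested is made for them only; others in the source may bear on it.

Compound 1 `COc1cc(N(C)CCN(C)C)c(NC(=O)/C=C\C(C)C)cc1Nc1nc(C)cc(-c2cn(C)c3ccccc23)n1` and compound 2 `CCC/C=C\C(=O)Nc1cc(Nc2nc(C)cc(-c3cn(C)c4ccccc34)n2)c(OC)cc1N(C)CCN(C)C` share one core and differ in a single place: propyl in place of isopropyl on a double-bonded chain carbon bound to a double-bonded chain carbon. In a functional assay on HepG2 cells (Homo sapiens) for antiproliferative activity, read by MTT assay, with a stated time of 72 h (a higher number here means a weaker inhibitor, a lower number a stronger inhibitor), compound 1 gives 3550 nM, whereas compound 2 gives 365 nM, a step of a 9.7-fold lower number from compound 1 to compound 2 (0.99 log units; beyond the scatter).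

Compound 3 `COc1cc(N(C)CCN(C)C)c(NC(=O)/C=C\C(C)C)cc1Nc1nccc(-c2cn(C)c3ccc(F)cc23)n1` is built on a different core; the difference between the two cores is not broken down here. In this assay compound 3 gives 3920 nM, the highest of the three numbers, lying within the scatter of compound 1 and well apart from compound 2.

Compound 4 `CCC/C=C\C(=O)Nc1cc(Nc2nccc(-c3cn(C)c4ccc(F)cc34)n2)c(OC)cc1N(C)CCN(C)C` has not yet been measured. It differs from compound 3 by propyl in place of isopropyl on a double-bonded chain carbon bound to a double-bonded chain carbon, the same change as that made from compound 1 to compound 2, at a place described in the same words. Within the data shown here, only one measured pair shows what this change does, so the expectation for the second core rests on a single precedent and carries that uncertainty. Compound 4 is expected to show a step of a 7.8-fold lower number from compound 3 to compound 4 (0.89 log units; beyond the scatter) because the same change gave a 9.7-fold lower number from compound 1 to compound 2 (0.99 log units; beyond the scatter). The estimate for compound 4 in this assay is 500 nM, with most repeats expected between 170 nM and 1500 nM.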

Compound 4, half-maximal inhibitory concentration: 3400 nM
Beside the measured number, compound 4's estimate is 6.8-fold (0.83 log units) below it, and the stated range ends below it.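

Carried to the second core, propyl in place of isopropyl on a double-bonded chain carbon bound to a double-bonded chain carbon gives in this assay a 1.2-fold lower number from compound 3 to compound 4 (0.06 log units; within the scatter), and the clear step seen on the first core does not reappear. The size of this change therefore does not carry over from one core to the other in these four compounds, and the two steps differ by more than repeated measurements would explain: the same change on two cores in this assay, a 9.7-fold lower number (0.99 log units; beyond the scatter) from compound 1 to compound 2 and a 1.2-fold lower number (0.06 log units; within the scatter) from compound 3 to compound 4, 8.4-fold (0.93 log units) apart, beyond the scatter of two such steps

What this does not show is which feature of the two cores separates the steps, as the difference between the cores is not broken down here. Two pairs also give no rule for any further core, and they say nothing about why the step appears on one core and not on the other.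

The compounds shown leave open whether the large step on the first core is particular to propyl or would also appear with a longer chain such as butyl, or with a cyclopropyl group, at the same place. They also leave open how such groups would behave on the second core, where propyl and isopropyl give numbers within the scatter of each other.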